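Ethoxy to Methoxy: What Compound 4 Might Show

The compounds below may be only part of what the source reports. "The series", "measured", "known", "first", "only" and "open" are said of these compounds alone.

Of the compounds shown here, three have been measured in a functional assay on U2OS cells for antagonist activity at C-X-C chemokine receptor type 3 (Homo sapiens), read by beta-arrestin recruitment; a higher number here means a weaker inhibitor, a lower number a stronger inhibitor. Compound 1 `C[C@@H]1CN(c2scnc2-c2nc3ccccc3[nH]2)CCN1C(=O)Cn1cnc2cccnc21` gives 830 nM, compound 2 `CC[C@@H]1CN(c2scnc2-c2nc3ccccc3[nH]2)CCN1C(=O)Cn1cnc2cccnc21` gives 604 nM, and compound 3 `CCOc1ncc(-c2nc(C(F)(F)F)sc2N2CCN(C(=O)Cn3nc(C)nc3C)[C@H](C)C2)cn1` gives 173 nM. The change from compound 2 to compound 1 is hydrogen in place of methyl on a saturated chain carbon bound to a saturated ring carbon and produced a 1.4-fold higher number from compound 2 to compound 1 (0.14 log units; within the scatter). The difference between the core of compound 3 and that of compound 2 is not broken down here. Compound 4 `COc1ncc(-c2nc(C(F)(F)F)sc2N2CCN(C(=O)Cn3nc(C)nc3C)[C@H](C)C2)cn1` is the untested analogue of compound 3; the change is hydrogen in place of methyl on a saturated chain carbon bound to an oxygen on an aromatic ring. It is the same kind of change as the earlier one, but the place differs: on a saturated chain carbon bound to a saturated ring carbon before, here on a saturated chain carbon bound to an oxygen on an aromatic ring. Compound 4 is expected to give 250 nM, between 100 nM and 650 nM. The expected step of a 1.4-fold higher number from compound 3 to compound 4 (0.16 log units; within the scatter) rests on the earlier step of a 1.4-fold higher number from compound 2 to compound 1 (0.14 log units; within the scatter) being within the scatter.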

Compound 4, half-maximal inhibitory concentration: 558 nM
Compound 4: middle estimate off by 2.2-fold (0.35 log units), on the low side; the measured number falls inside the stated range.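

In this assay, going from ethoxy to methoxy gives a 3.2-fold higher number from compound 3 to compound 4 (0.51 log units; beyond the scatter), so here the loss of one methyl leaves a weaker inhibitor. Set beside the same change at the other place, on the other core, the two steps cannot be told apart: the same change on two cores in this assay, a 1.4-fold higher number (0.14 log units; within the scatter) from compound 2 to compound 1 and a 3.2-fold higher number (0.51 log units; beyond the scatter) from compound 3 to compound 4, 2.3-fold (0.37 log units) apart, within the scatter of two such steps. This gives no sign that the core alters the effect of the change, but two pairs that also differ in where the change sits do not show that it carries over at a fixed size, and only the new step lies beyond the scatter.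

The compounds shown leave open whether a longer chain, such as propoxy, or an amine in place of ethoxy would match compound 3. They also leave open how the same change would read on a third core.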